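The source may report more compounds than this note shows. Statements on the series, on what has been measured and on what is new or still open speak of the compounds shown alone.

Three compounds share one core and differ only in the group on a saturated chain carbon bound to an aromatic carbon and a saturated chain carbon. Compound 1 `CC(C)C(c1nnc[nH]1)c1ccc(-c2ccc3cccc(F)c3c2)[nH]c1=O` gives 21 nM in a functional assay on CHO cells for antagonist activity at prostaglandin E2 receptor EP3 subtype (Homo sapiens), read by cAMP accumulation; on this read-out lower numbers stand for stronger inhibition and higher numbers for weaker inhibition. Compound 2 `CC(C)C(c1ccc(-c2ccc3cccc(F)c3c2)[nH]c1=O)N1CCCCC1=O` gives 40 nM in this assay, and compound 3 `CC(C)C(c1noc(=O)[nH]1)c1ccc(-c2ccc3cccc(F)c3c2)[nH]c1=O` gives 41 nM in this assay. The three numbers lie within the scatter of one another: a 1.9-fold higher number from compound 1 to compound 2 (0.28 log units; within the scatter), a 2.0-fold higher number from compound 1 to compound 3 (0.29 log units; within the scatter) and a 1.0-fold higher number from compound 2 to compound 3 (0.01 log units; within the scatter). Compound 4 `Cc1c[nH]c(C(c2ccc(-c3ccc4cccc(F)c4c3)[nH]c2=O)C(C)C)n1` is not yet measured. It differs from compound 3 in one place: a group of 6 heavy atoms (4 carbon, 2 nitrogen; one five-membered aromatic ring with 2 hetero atoms) in place of a group of 6 heavy atoms (2 carbon, 2 nitrogen, 2 oxygen; one five-membered aromatic ring with 3 hetero atoms), on a saturated chain carbon bound to an aromatic carbon and a saturated chain carbon. Every measured step exchanges the group on that same carbon, and none of those exchanges reaches beyond the scatter, so a further exchange at that carbon is expected to leave the number roughly where it stands. Compound 4 is therefore expected to give 30 nM in this assay, with a likely range from 10 nM to 100 nM, which amounts to an expected step of a 1.4-fold lower number from compound 3 to compound 4 (0.14 log units; within the scatter).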

Compound 4, half-maximal inhibitory concentration: 36 nM
The estimate for compound 4 lay 1.2-fold (0.08 log units) below the measured number, within the range that was stated.
By their numbers in this assay, from the lowest: compounds 1, 4, 2 and 3 (each within the scatter of the next).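

Exchanging the ring of compound 3 for 4-methyl-1H-imidazol-2-yl removes both oxygens and takes the hydrogen-bond acceptors from 3 to 1, yet it gives a 1.1-fold lower number from compound 3 to compound 4 (0.06 log units; within the scatter) in this assay on this carbon. Set against the other two groups, the new one also stays within the scatter, with a 1.1-fold lower number from compound 2 to compound 4 (0.05 log units; within the scatter) and a 1.7-fold higher number from compound 1 to compound 4 (0.23 log units; within the scatter) as the steps. The carbon bound to an aromatic carbon and a saturated chain carbon therefore accepts a ring bearing a methyl group without leaving the scatter, a case the earlier three compounds did not include.

The compounds shown leave open whether a carboxylic acid, an amine or an open longer chain on this carbon would also stay within the scatter. Nothing available here explains why these four groups read alike.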